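Acetylating a tertiary hydroxyl in a taxane-type ester series

A few compounds are considered here, and "the series" means these few. Any claim that something is new, unique, unknown or untested is made for them only; others in the source may bear on it.

Of the compounds shown here, two of a shared core have been tested in a functional assay on MCF7 cells (Homo sapiens) for antiproliferative activity, read by MTT assay, with a stated time of 48 h; on this read-out higher numbers stand for weaker inhibition and lower numbers for stronger inhibition. Compound 1, with structure `C=C1[C@H](OC(C)=O)[C@@H](OC(=O)C(C)(C)C)[C@@H](OC(C)=O)C(C)(C)/C=C/[C@H](C)[C@H](OC(=O)c2ccccc2)[C@@]2(O)C[C@@](C)(OC(C)=O)[C@H](OC(C)=O)[C@@H]2[C@H]1OCC(C)C`, reaches only the limit of the assay: in this assay compound 1 gives > 100000 nM. Going by the values given here, compound 2, with structure `C=C1[C@H](OC(C)=O)[C@@H](OC(=O)c2cccc(C)c2)[C@@H](OC(C)=O)C(C)(C)/C=C/[C@H](C)[C@H](OC(=O)c2ccccc2)[C@@]2(O)C[C@@](C)(O)[C@H](OC(C)=O)[C@@H]2[C@H]1OCC(C)C`, is the one that gives a number; in this assay compound 2 gives 23400 nM. Among the compounds with values here, compound 2 therefore stands as the only measured number among the two values shown, with the other value sitting at the upper limit (the limit of > 100000 nM in this assay, at which 1 of the 2 values shown sits). Within the data shown here, compound 1 and compound 2 differ in two places at once, so no single step between them can be read.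

Compound 3, with structure `C=C1[C@H](OC(C)=O)[C@@H](OC(=O)c2cccc(C)c2)[C@@H](OC(C)=O)C(C)(C)/C=C/[C@H](C)[C@H](OC(=O)c2ccccc2)[C@@]2(O)C[C@@](C)(OC(C)=O)[C@H](OC(C)=O)[C@@H]2[C@H]1OCC(C)C`, comes from compound 2 by one change: acetyl in place of hydrogen on an oxygen on a saturated carbon, turning a hydroxy into an acetoxy. Among the measured compounds shown here, the two values that exist give no measured step for this change, so the expectation for compound 3 rests on the weak signal from compound 2 alone and is loose. Compound 3 is expected to be somewhat weaker, a step of a 2.1-fold higher number from compound 2 to compound 3 (0.33 log units; beyond the scatter) from compound 2. The estimate for compound 3 in this assay is 50000 nM, within a range from 15000 nM to 150000 nM.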

Compound 3, half-maximal inhibitory concentration: > 100000 nM
Compound 3: no number, only a limit; the forecaster's own chance of this, stated with the estimate: 35%; middle value at least 2.0-fold (0.30 log units) from the limit.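

Going by these compounds alone, this gives the first readable step at this position. In this assay, turning the hydroxy into an acetoxy, on an oxygen on a saturated carbon, gives an at least 4.2-fold higher number from compound 2 to compound 3 (0.63 log units; beyond the scatter), so among the compounds shown, a measurable number appears only with the free hydroxy. Compound 3 gives > 100000 nM, which is a limit of the assay and not a number, so the step sets only a minimum size and the real loss could be larger. The change from tert-butyl to 3-methylphenyl on a carbonyl carbon cannot be read, and most of the series now rests at the top of the assay's range: the limit of > 100000 nM in this assay, at which 2 of the 3 values shown sit.

From the compounds shown here alone, it remains open whether this loss is specific to acetyl or would also follow from another group on this oxygen, such as a methyl ether or a longer butyryl ester, or from an amine in place of the hydroxy. It is also open whether 3-methylphenyl contributes to the number seen for compound 2, as the compounds shown do not test tert-butyl alongside the free hydroxy.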